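Swapping benzyloxy for an imidazole on a fast-cleared compound

The compounds below may be only part of what the source reports. "The series", "measured", "known", "first", "only" and "open" are said of these compounds alone.

- compound 1 `CNC(=O)[C@@H]1CCCN1S(=O)(=O)c1ccc(Cl)c(COc2cccc3c(-c4cncn4C)cc(C)nc23)c1Cl`: 33.3 mL/min/kg
- compound 2 `CNC(=O)[C@@H]1CCCN1S(=O)(=O)c1ccc(Cl)c(COc2cccc3c(-c4ccncc4)cc(C(C)C)nc23)c1Cl`: 333 mL/min/kg
- compound 3 `CNC(=O)[C@@H]1CCCN1S(=O)(=O)c1ccc(Cl)c(COc2cccc3c(OCc4ccccc4)cc(C(C)C)nc23)c1Cl`: 667 mL/min/kg
- compound 4 `CNC(=O)[C@@H]1CCCN1S(=O)(=O)c1ccc(Cl)c(COc2cccc3c(-c4cncn4C)cc(C(C)C)nc23)c1Cl`: not yet measured

In an ADME assay on microsomes (Homo sapiens) for metabolic stability (a higher number here means faster removal of the compound, a lower number slower removal), compound 3 gives 667 mL/min/kg. That lies within the scatter of compound 2 at 333 mL/min/kg and well away from compound 1 at 33.3 mL/min/kg.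

The next compound, compound 4, replaces one group of compound 3: 1-methyl-1H-imidazol-5-yl in place of benzyloxy on an aromatic carbon. In short, 1-methyl-1H-imidazol-5-yl stands in place of benzyloxy on an aromatic carbon.

Among the measured compounds shown here, only one measured step changes this same spot, a 2.0-fold higher number from compound 2 to compound 3 (0.30 log units; within the scatter), and it stays within the scatter. It says little about the new group. For the measured compounds named here, compound 1 is the only measured compound with 1-methyl-1H-imidazol-5-yl, and it gives 33.3 mL/min/kg, but it lacks the isopropyl group that compound 2, compound 3 and compound 4 all carry. A fall beyond the scatter is therefore expected, though probably not all the way to the number of compound 1. The expected change is a 5.1-fold lower number from compound 3 to compound 4 (0.71 log units; beyond the scatter). For compound 4 the estimated clearance is 130 mL/min/kg, with an expected range of 50 mL/min/kg to 350 mL/min/kg.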

Compound 4, clearance: 33.3 mL/min/kg
Compound 4: middle estimate off by 3.9-fold (0.59 log units), on the high side; measured number outside the range, below it.
By their numbers in this assay, from the lowest: compounds 1 and 4 (each within the scatter of the next); then compounds 2 and 3 (each within the scatter of the next).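

In this assay, the group on the aromatic carbon opposite the ring nitrogen proves to have a large effect: 1-methyl-1H-imidazol-5-yl brings a 20-fold lower number from compound 3 to compound 4 (1.30 log units; beyond the scatter) and a 10-fold lower number from compound 2 to compound 4 (1.00 log units; beyond the scatter), whereas the earlier exchange of the other two groups gave only a 2.0-fold higher number from compound 2 to compound 3 (0.30 log units; within the scatter). With 1-methyl-1H-imidazol-5-yl in place, isopropyl in place of methyl gives no change at the digits printed from compound 1 to compound 4 (within the scatter), so the isopropyl group does not keep the number up in this pair. Nothing measured here explains the large effect of the imidazole.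

As far as these compounds go, it remains open whether this result is particular to 1-methyl-1H-imidazol-5-yl, or whether another group at this position, such as an amine or a simple methoxy group, would give a similar number. A longer chain in place of isopropyl also remains to be compared.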